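Amide substituent swap on a diaryl thiophene scaffold

The source may report more compounds than this note shows. Statements on the series, on what has been measured and on what is new or still open speak of the compounds shown alone.

Measured compounds: compound 1 `CC(C)(C)NC(=O)c1c(N)sc(-c2ccc(Cl)cc2)c1-c1ccc(Cl)cc1` gives 8850 nM in a functional assay on A549 cells (Homo sapiens) for inhibition, read by sulforhodamine B assay, with a stated time of 72 h; a lower number here means a stronger inhibitor, a higher number a weaker inhibitor; compound 2 `CCOC(=O)Nc1sc(-c2ccc(Cl)cc2)c(-c2ccc(Cl)cc2)c1C(=O)NC1CC1` gives 39800 nM; compound 3 `Nc1sc(-c2ccc(Cl)cc2)c(-c2ccc(Cl)cc2)c1C(=O)NC1CCCC1` gives 6790 nM.

Compound 3 has the lowest number of the three, but its gap to compound 1 is within the scatter, and only compound 2 stands apart, beyond the scatter. Compound 4 `Nc1sc(-c2ccc(Cl)cc2)c(-c2ccc(Cl)cc2)c1C(=O)NC1CC1` arises from compound 3 by cyclopropyl in place of cyclopentyl on an amide-type nitrogen. Going by the values given here, the one comparable step, a 1.3-fold lower number from compound 1 to compound 3 (0.12 log units; within the scatter), is within the scatter, so a change of this kind at the amide-type nitrogen has so far moved the number little. Compound 2 differs from compound 4 in more than one place, so its value alone cannot set the step. The expected step is a 1.3-fold higher number from compound 3 to compound 4 (0.12 log units; within the scatter), with little change beyond the scatter. Compound 4 is therefore estimated at 9000 nM, between 3500 nM and 25000 nM.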

Compound 4, half-maximal inhibitory concentration: 1950 nM
Estimate against measurement, compound 4: 4.6-fold (0.66 log units) above, outside the stated range (below it).
By their numbers in this assay, from the lowest: compound 4; then compounds 3 and 1 (each within the scatter of the next); then compound 2.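

At the amide-type nitrogen, cyclopropyl stands apart from both larger groups in this assay, with a 3.5-fold lower number from compound 3 to compound 4 (0.54 log units; beyond the scatter) and a 4.5-fold lower number from compound 1 to compound 4 (0.66 log units; beyond the scatter) showing that this position can move the number beyond the scatter. On the nitrogen on an aromatic ring, hydrogen in place of ethoxycarbonyl gives the largest step, a 20-fold lower number from compound 2 to compound 4 (1.31 log units; beyond the scatter). No evidence is available that explains these steps. The compounds shown leave open how cyclobutyl or a straight ethyl chain would behave at the amide-type nitrogen. They also leave open whether an acetyl group on the nitrogen on an aromatic ring would give a similar step.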